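A few compounds are considered here, and "the series" means these few. Any claim that something is new, unique, unknown or untested is made for them only; others in the source may bear on it.

Measured compounds:
compound 1 `CC1=CC[C@H](C(C)C)c2cc(C)c(OC(=O)c3cccc(C)c3)cc21` with 38.6%
compound 2 `Cc1cc2c(C(C)C)ccc(C)c2cc1OC(=O)c1ccc([N+](=O)[O-])cc1` with 100%

In a functional assay on PC-3 cells (Homo sapiens) for antiproliferative activity, read by sulforhodamine B assay, with a stated time of 48 h, tested at 50 uM (a lower number here means less inhibition, a higher number more inhibition at the concentration tested (going by the name of the read-out)), compound 1 gives 38.6% and stands lowest of the two numbers; compound 2 sits far higher, beyond the scatter, though the two differ in more than one place. Compound 3 `CC1=CC[C@H](C(C)C)c2cc(C)c(OC(=O)c3cccc([N+](=O)[O-])c3)cc21` is not yet measured. It differs from compound 1 by nitro in place of methyl on an aromatic carbon. For the measured compounds named here, with no single-change step known, the writer expects an upward step in this assay, larger than the scatter, since compound 2, which also bears a nitro group, gives 100%. For compound 3 the estimate in this assay is 65%, with a range from 35% to 95%, a step of a number 26.4 percentage points higher from compound 1 to compound 3 (beyond the scatter).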

Compound 3, a percentage reported as inhibition, at one concentration (the size of the read-out at that concentration, not a potency): 36.9%
For compound 3 the middle estimate is 28.1 percentage points above the measured one; low and high end bracket the measured number.
By their numbers in this assay, from the lowest: compounds 3 and 1 (each within the scatter of the next); then compound 2.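

In this assay the change from 3-methylphenyl to 3-nitrophenyl on the core of compound 1 gives a number 1.7 percentage points lower from compound 1 to compound 3 (within the scatter) and so brings no readable change at the concentration tested. At this place, meta to a large group, nitro and methyl cannot be told apart in this read-out. Nothing measured on these compounds offers an explanation for this result. Going by these compounds, whether an amine or a carboxylic acid at this place would move the number stays open. So does whether nitro would give the same result elsewhere on this ring.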